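Fluoro in place of methoxymethyl: working notes

A few compounds are considered here, and "the series" means these few. Any claim that something is new, unique, unknown or untested is made for them only; others in the source may bear on it.

Measured so far:
compound 1, `COCc1ccccc1C1CCc2nc[nH]c2C1`, 87%; 83% (2 entries)
compound 2, `COCc1ccccc1C1Cc2nccn2C1`, 77%

In a functional assay on CHO cells for agonist activity at Alpha-1A adrenergic receptor (Homo sapiens), read by FLIPR and calcium flux (on this read-out higher numbers stand for larger maximal responses and lower numbers for smaller maximal responses), compound 1 gives 87%; 83% (2 entries), and compound 2 gives 77%. The repeated entries of compound 1, (the several entries of compound 1 in this assay, 87%; 83% (2 entries)), lie within the usual scatter of each other. For the measured compounds named here, for compound 2 this is the only number recorded; a further entry for it reports no number. Going by the values given here, the two compounds share no single-point change, so no measured step is available.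

Compound 3, `Fc1ccccc1C1Cc2nccn2C1`, has not yet been measured. It differs from compound 2 by fluoro in place of methoxymethyl on an aromatic carbon. Among the compounds with values here, no measured pair covers this change, so the expectation rests on the single value of compound 2 alone.

The step from compound 2 to compound 3 is expected to be small, a number 2 percentage points lower from compound 2 to compound 3 (within the scatter), not beyond the scatter in either direction. Compound 3 is accordingly estimated at 75%, with a range from 55% to 95%.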

Compound 3, largest response reached (Emax), in percent of the reference or control that the assay uses: 63%
For compound 3 the middle estimate is 12 percentage points above the measured one; the measured number falls inside the stated range.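

The aromatic carbon ortho to a group of 8 heavy atoms now has its first measured step in this assay, a number 14 percentage points lower from compound 2 to compound 3 (beyond the scatter). The maximal response therefore depends on what sits at this position, and fluoro does not stand in for methoxymethyl without a change in the read-out. The step exceeds the spread between repeat entries of a single compound: the several entries of compound 1 in this assay, 87%; 83% (2 entries)

This one pair cannot separate the loss of the oxygen from the loss of chain length or from the arrival of fluorine, and no measurement here gives a reason for the step. From the compounds shown here alone, it remains open whether methyl, methoxy or hydroxymethyl on the same carbon would stay closer to compound 2, and whether the same change would give a similar step on the core of compound 1.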